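Methoxy to Hydroxy on a Pyridyl-Pyrazole Urea

This account rests on a few compounds, and the source may have more. Where it says the series, first, only, none or still open, it means among the compounds named here.

Of the compounds shown here, two have been measured in a functional assay on U-251 cells (Homo sapiens) for inhibition, read by sulforhodamine B assay, with a stated time of 48 h; on this read-out lower numbers stand for stronger inhibition of growth and higher numbers for weaker inhibition of growth. Compound 1 `O=C(Nc1cccc(-n2cc(-c3ccncc3)c(-c3ccc(Cl)c(O)c3)n2)c1)Nc1cccc(C(F)(F)F)c1` gives 1590 nM. Compound 2 `COc1cc(-c2nn(-c3cccc(NC(=O)Nc4cc(C(F)(F)F)cc(C(F)(F)F)c4)c3)cc2-c2ccncc2)ccc1Cl` gives 590 nM, the lower of the two numbers; compound 1 sits higher, by a gap beyond the usual scatter. The two compounds differ at more than one place, so no single change can be read from that gap.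

Compound 3 `O=C(Nc1cccc(-n2cc(-c3ccncc3)c(-c3ccc(Cl)c(O)c3)n2)c1)Nc1cc(C(F)(F)F)cc(C(F)(F)F)c1` has not been measured. It differs from compound 2 in one place: hydrogen in place of methyl on an oxygen on an aromatic ring, that is, methoxy to hydroxy on the 4-chloro-3-methoxyphenyl ring, which becomes 4-chloro-3-hydroxyphenyl. For the measured compounds named here, compound 1 carries the same hydroxy group, but it also differs from compound 3 elsewhere, so no measured pair isolates this change.

With nothing to anchor it, the step of a 1.4-fold higher number from compound 2 to compound 3 (0.16 log units; within the scatter) is expected to be small, most likely a modest weakening that stays near the scatter. Compound 3 is therefore estimated at 850 nM, with a plausible range from 300 nM to 2500 nM.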

Compound 3, concentration for 50% growth inhibition: 463 nM
Compound 3: the middle estimate sits 1.8-fold (0.26 log units) above what was measured, within the range that was stated.
By their numbers in this assay, from the lowest: compounds 3 and 2 (each within the scatter of the next); then compound 1.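

In this assay, putting hydrogen in place of methyl on the oxygen, so that 4-chloro-3-methoxyphenyl becomes 4-chloro-3-hydroxyphenyl, gives a 1.3-fold lower number from compound 2 to compound 3 (0.11 log units; within the scatter). For the compounds shown here, at this position, then, methoxy and hydroxy cannot be told apart on growth inhibition in these cells, a point that could not be read before, when no measured pair isolated this change. Compound 3 also creates a second single-place comparison, trifluoromethyl in place of hydrogen on an aromatic carbon, which gives a 3.4-fold lower number from compound 1 to compound 3 (0.54 log units; beyond the scatter), so of the two single changes now available, only this one goes beyond the usual scatter, although its size rests on one pair, with the hydroxy group present in both compounds.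

The compounds shown leave open whether a larger group on the same oxygen, such as ethoxy or a longer chain, or an amine in place of the hydroxy, would stay equally close to these values. They also leave open whether the trifluoromethyl step would hold with methoxy on the ring, and no measurement at hand explains either step.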